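How Well Might Cells Tolerate Compound 3?

The compounds below may be only part of what the source reports. "The series", "measured", "known", "first", "only" and "open" are said of these compounds alone.

Compound 1 `COC(=O)c1ccc(NC(=O)CSc2nc3ccccc3n2S(=O)(=O)c2cc(C)cc(C)c2)cc1` gives 10000 nM
Compound 2 `Cc1cc(C)cc(S(=O)(=O)n2c(OCC(=O)Nc3ccc(S(N)(=O)=O)cc3Cl)nc3ccccc32)c1` gives > 227000 nM as a limit of the assay

Within the data shown here, in an ADME assay on MT4 cells (Homo sapiens) for cytotoxicity, read by MTT assay, with a stated time of 5 days (a higher number here means that more compound is tolerated, a lower number that less compound is tolerated), compound 1 gives 10000 nM as the only actual number so far. The other reading, for compound 2, is > 227000 nM and is a limit, not a number. Compound 3 `Cc1cc(C)cc(S(=O)(=O)n2c(SCC(=O)Nc3ccc(S(N)(=O)=O)cc3Cl)nc3ccccc32)c1` keeps the core of compound 1 and changes one group: 2-chloro-4-sulfamoylphenyl in place of 4-(methoxycarbonyl)phenyl on an amide-type nitrogen. Among the measured compounds shown here, no measured step between two compounds is available to guide the expectation. Compound 2 also carries 2-chloro-4-sulfamoylphenyl, and its limit of > 227000 nM is the only hint available. A rise in this assay is therefore expected, meaning more compound tolerated, and the estimated size is a 5.0-fold higher number from compound 1 to compound 3 (0.70 log units; beyond the scatter) with wide uncertainty. Compound 3 is expected at 50000 nM in this estimate, within an estimated range from 10000 nM to 227000 nM and possibly reported only as a limit.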

Compound 3, half-maximal cytotoxic concentration: 25600 nM
Estimate against measurement, compound 3: 2.0-fold (0.29 log units) above; the range from low to high includes it.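

In this assay, placing 2-chloro-4-sulfamoylphenyl instead of 4-(methoxycarbonyl)phenyl on the amide-type nitrogen gives a 2.6-fold higher number from compound 1 to compound 3 (0.41 log units; beyond the scatter). Among these compounds, this is the first measured step at this position, and it shows that the group held there can shift how much compound the cells tolerate, by a modest amount that still lies beyond the usual scatter. Compound 2 carries the same 2-chloro-4-sulfamoylphenyl group, but its reading is a limit and not a number: the limit of > 227000 nM in this assay, at which 1 of the 3 values shown sits.

The entering group differs from the leaving one in both its chlorine and its sulfamoyl group, and this single step cannot separate what each contributes. From the compounds shown here alone, how cells would tolerate a compound with a plain phenyl, or a phenyl bearing a carboxylic acid or an amine, at this position remains open.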